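From pyridin-2-yl to carbamoyl on the same nitrogen

The compounds below may be only part of what the source reports. "The series", "measured", "known", "first", "only" and "open" are said of these compounds alone.

In a functional assay on SK-OV-3 cells (Homo sapiens) for cytotoxicity, read by MTT assay, with a stated time of 3 days (a higher number here means a weaker inhibitor, a lower number a stronger inhibitor), compound 1 `N#Cc1c(NN)nc(SCc2nc3ccccc3[nH]2)nc1-c1ccccc1` gives 2.7 nM, while compound 2 `N#Cc1c(Nc2ccccn2)nc(SCc2nc3ccccc3[nH]2)nc1-c1ccccc1` gives 5.81 nM, the higher of the two numbers. Compound 3 `N#Cc1c(NC(N)=O)nc(SCc2nc3ccccc3[nH]2)nc1-c1ccccc1` carries carbamoyl in place of pyridin-2-yl on a nitrogen on an aromatic ring. Among the measured compounds shown here, only one measured step bears on this change (a 2.2-fold higher number from compound 1 to compound 2 (0.33 log units; beyond the scatter)), a modest one that brought the pyridin-2-yl in, and carbamoyl itself remains untested. A small move towards a lower number is therefore expected (a 1.5-fold lower number from compound 2 to compound 3 (0.16 log units; within the scatter)). The estimated value for compound 3 is 4 nM (expected range 1.5 nM to 12 nM).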

Compound 3, half-maximal inhibitory concentration: 6.75 nM
Compound 3: the middle estimate sits 1.7-fold (0.23 log units) below what was measured; the measured number falls inside the stated range.
By their numbers in this assay, from the lowest: compound 1; then compounds 2 and 3 (each within the scatter of the next).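

In this assay, replacing pyridin-2-yl with carbamoyl on this nitrogen gives a 1.2-fold higher number from compound 2 to compound 3 (0.07 log units; within the scatter), so a group with no ring matches the aromatic one here. Carbamoyl in place of amino gives a 2.5-fold higher number from compound 1 to compound 3 (0.40 log units; beyond the scatter), which puts carbamoyl, like pyridin-2-yl, on the higher side of compound 1. No measurement shown here offers an explanation for these numbers. From the compounds shown here alone, it remains open whether an acetyl or a methyl on this nitrogen would stay with compound 2 and compound 3 or come closer to compound 1.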